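The source may report more compounds than this note shows. Statements on the series, on what has been measured and on what is new or still open speak of the compounds shown alone.

Measured in a functional assay on DU-145 cells (Homo sapiens) for antiproliferative activity, read by sulforhodamine B assay, with a stated time of 48 h; a higher number here means a weaker inhibitor, a lower number a stronger inhibitor:
- compound 1 `CCCCN(C)C(=O)CCCCOc1cc(OC)c(OC)c2oc(-c3ccc(OC)cc3)c(O)c(=O)c12`: 10800 nM
- compound 2 `COc1ccc(-c2oc3c(OC)c(OC)cc(OCCCCC(=O)NCc4ccccn4)c3c(=O)c2O)cc1`: > 40000 nM (a limit of the assay, not a number)
- compound 3 `COc1ccc(-c2oc3c(OC)c(OC)cc(OCCCCC(=O)N4CCN(C)CC4)c3c(=O)c2O)cc1`: > 40000 nM (a limit of the assay, not a number)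

Compound 3 has no exact value and stands at the limit of > 40000 nM in this assay, at which 2 of the 3 values shown sit. Compound 4 `COc1ccc(-c2oc3c(OC)c(OC)cc(OCCCCCC(=O)NCc4ccccn4)c3c(=O)c2O)cc1` differs from it as follows: (((pyridin-2-yl)methyl)carbamoyl)methyl in place of (4-methylpiperazin-1-yl)carbonyl on a saturated chain carbon, four bonds along the chain from an oxygen on an aromatic ring. In words, (((pyridin-2-yl)methyl)carbamoyl)methyl comes in place of (4-methylpiperazin-1-yl)carbonyl on a saturated chain carbon, four bonds along the chain from an oxygen on an aromatic ring.

Among the compounds with values here, three measured steps bear on this change. Replacing butyl(methyl)amino with ((pyridin-2-yl)methyl)amino gave an at least 3.7-fold higher number from compound 1 to compound 2 (0.56 log units; beyond the scatter), and replacing it with 4-methylpiperazin-1-yl gave an at least 3.7-fold higher number from compound 1 to compound 3 (0.56 log units; beyond the scatter). Both moved towards weaker inhibition. The two groups themselves cannot be ranked, as the data show a step that the two limits leave unreadable from compound 2 to compound 3. The ((pyridin-2-yl)methyl)amino group also forms part of the group entering compound 4, so weak inhibition is expected to persist, on the evidence of an at least 3.7-fold higher number from compound 1 to compound 2 (0.56 log units; beyond the scatter). No clear gain is expected, and a reading that is again only a limit is the likeliest outcome. The expected change is an at least 1.1-fold lower number from compound 3 to compound 4 (0.05 log units; that floor lies within the scatter), and its size is unlikely to be readable. For compound 4 the estimated value is 35000 nM, with an expected range from 12000 nM to 80000 nM.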

Compound 4, half-maximal inhibitory concentration: > 40000 nM
Compound 4 ended at the assay's limit (the forecaster's own chance of this, stated with the estimate: 60%); at least 1.1-fold (0.05 log units) between middle value and limit.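

In this assay compound 4 gives > 40000 nM, which is a limit of the assay and not a number. Within the data shown here, exchanging the butyl(methyl)carbamoyl group for (((pyridin-2-yl)methyl)carbamoyl)methyl gives an at least 3.7-fold higher number from compound 1 to compound 4 (0.56 log units; beyond the scatter), so the ((pyridin-2-yl)methyl) amide stays weak here even when it sits on a longer chain, which the earlier compounds could not show. The steps from compound 2 and from compound 3 to compound 4 cannot be read, as both ends of each are limits, and the only exact reading among these compounds remains that of compound 1: the limit of > 40000 nM in this assay, at which 3 of the 4 values shown sit.

Going by these compounds, whether chain length matters at all stays open, since the two compounds that differ in chain length both sit at the limit, so any difference between them is hidden. The same longer chain ending in the butyl(methyl)carbamoyl group of compound 1 could answer this with a real number, and a chain ending in a carboxylic acid or a simple dimethylamide would show how much of the activity of compound 1 depends on its butyl group.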